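Swapping a trifluoromethyl tail for a diazepane in compound 4

The source may report more compounds than this note shows. Statements on the series, on what has been measured and on what is new or still open speak of the compounds shown alone.

Measured so far:
compound 1 `Cc1ccc(NC(=O)c2ccc(C(F)(F)F)cc2)cc1-n1cc(-c2cnc3cccnn23)cn1` gives 10500 nM in a functional assay on K562 cells (Homo sapiens) for antiproliferative activity, read by CCK-8 assay, with a stated time of 24 h; on this read-out lower numbers stand for stronger inhibition and higher numbers for weaker inhibition;
compound 2 `Cc1ccc(NC(=O)c2cccc(Cl)c2)cc1-n1cc(-c2cnc3cccnn23)cn1` gives 5080 nM;
compound 3 `Cc1ccc(NC(=O)c2ccc(C(F)(F)F)cc2)cc1-n1cc(-c2cnc3ccnn3c2)cn1` gives 6930 nM.

Compound 3 sits between the other two, within the scatter of both. Compound 4 `Cc1ccc(NC(=O)c2ccc(CN3CCCN(C)CC3)cc2)cc1-n1cc(-c2cnc3ccnn3c2)cn1` differs from compound 3 by (4-methyl-1,4-diazepan-1-yl)methyl in place of trifluoromethyl on an aromatic carbon. For the measured compounds named here, no measured step changes this part of the molecule; the only step at the amide-bearing ring, a 2.1-fold lower number from compound 1 to compound 2 (0.32 log units; beyond the scatter), was modest, and the step of a 1.5-fold lower number from compound 1 to compound 3 (0.18 log units; within the scatter) touched another group and stayed within the scatter. The change in compound 4 is far larger than either, so the direction is uncertain, and a modest improvement is expected, a 2.0-fold lower number from compound 3 to compound 4 (0.30 log units; within the scatter). Compound 4 is therefore estimated at 3500 nM, within 1000 nM to 12000 nM.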

Compound 4, half-maximal inhibitory concentration: 5880 nM
Compound 4: middle estimate off by 1.7-fold (0.23 log units), on the low side, and the stated range covers the measured number.
By their numbers in this assay, from the lowest: compounds 2, 4, 3 and 1 (each within the scatter of the next, the first and the last beyond it).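

Putting (4-methyl-1,4-diazepan-1-yl)methyl, with its seven-membered non-aromatic ring, where trifluoromethyl stood gives a 1.2-fold lower number from compound 3 to compound 4 (0.07 log units; within the scatter) in this assay. So this aromatic carbon accepts a much larger group, with more heavy atoms and a ring, without a readable change in the number. No measurement at hand accounts for this result. Still open, as far as these compounds go, is whether a smaller piperazine or morpholine, or a carboxylic acid, at this position would move the number beyond the scatter. Also open, from the compounds shown here alone, is whether the same exchange on the core of compound 1 would behave alike.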